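Triazole aryl variation in the antiproliferative series

This account rests on a few compounds, and the source may have more. Where it says the series, first, only, none or still open, it means among the compounds named here.

Measured so far:
compound 1 `CC(C)(C)c1cn(C[C@H](O)[C@H]2OC(=O)C(OCc3ccccc3)=C2OCc2ccccc2)nn1`: 54900 nM
compound 2 `O=C1O[C@H]([C@@H](O)Cn2cc(-c3cccc(O)c3)nn2)C(OCc2ccccc2)=C1OCc1ccccc1`: 54100 nM
compound 3 `Cc1ccc(-c2cn(C[C@H](O)[C@H]3OC(=O)C(OCc4ccccc4)=C3OCc3ccccc3)nn2)cc1`: a limit, > 100000 nM

In a functional assay on CFPAC-1 cells (Homo sapiens) for antiproliferative activity, read by MTT assay, with a stated time of 72 h (a lower number here means a stronger inhibitor, a higher number a weaker inhibitor), compound 1 gives 54900 nM. Compound 2 gives 54100 nM, and the step of a 1.0-fold lower number from compound 1 to compound 2 (0.01 log units; within the scatter) is within the scatter. Compound 3 gives only a limit of the assay, > 100000 nM. Compound 3 therefore stands at the limit of > 100000 nM in this assay, at which 1 of the 3 values shown sits, and has no number of its own. The steps of an at least 1.8-fold higher number from compound 1 to compound 3 (0.26 log units; that floor lies within the scatter) and an at least 1.8-fold higher number from compound 2 to compound 3 (0.26 log units; that floor lies within the scatter) are floors that lie within the scatter, so compound 3 cannot be separated from the other two on the numbers shown; all three sit at weak inhibition.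

Compound 4 `O=C1O[C@H]([C@@H](O)Cn2cc(-c3ccc(Br)cc3)nn2)C(OCc2ccccc2)=C1OCc1ccccc1` differs from compound 3 by bromo in place of methyl on an aromatic carbon. The steps bearing on this position are those into compound 3, and both were small floors. Within the data shown here, no measured step exchanges one substituent on this six-membered ring for another, so no direction is indicated, and no step beyond the scatter is expected in this assay. Compound 4 is estimated to give about 100000 nM, with a range from 40000 nM to 250000 nM. The expected step is a number no higher from compound 3 to compound 4 (the limit leaves the size open), and a further limit rather than a number is a real possibility.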

Compound 4, half-maximal inhibitory concentration: 5830 nM
Beside the measured number, compound 4's estimate is 17-fold (1.23 log units) above it; measured number outside the range, below it.
By their numbers in this assay, from the lowest: compound 4; then compounds 2 and 1 (each within the scatter of the next). At a limit, above all of these: compound 3.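

In this assay, bromo in place of methyl on the aromatic carbon gives an at least 17-fold lower number from compound 3 to compound 4 (1.23 log units; beyond the scatter), so this position of the six-membered aromatic ring can separate compounds in the series, although the exchange leaves the heavy-atom count unchanged and adds no hydrogen-bond donor or acceptor. Among these compounds, compound 4 also stands apart from the other two triazole substituents, with a 9.3-fold lower number from compound 2 to compound 4 (0.97 log units; beyond the scatter) and a 9.4-fold lower number from compound 1 to compound 4 (0.97 log units; beyond the scatter), whereas the earlier steps among 3-hydroxyphenyl, tert-butyl and 4-methylphenyl gave no such separation. The true size of the methyl-to-bromo step remains open, as compound 3 has no number of its own and carries only a limit: the limit of > 100000 nM in this assay, at which 1 of the 4 values shown sits.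

The compounds shown do not tell whether this gain belongs to bromo alone or extends to other groups at the same place, such as chloro, fluoro, methoxy, nitrile or an amine. They also leave open whether 4-bromophenyl would give a step of similar size on a different core or in a different cell line.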